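The compounds below may be only part of what the source reports. "The series", "measured", "known", "first", "only" and "open" are said of these compounds alone.

Compound 1, `NS(=O)(=O)c1sc(Cl)cc1-c1csc(-c2ccccc2COc2ccc(Cl)cc2)n1`: 76.4%
Compound 2, `Clc1ccc(OCc2csc(-c3ccccc3COc3ccc(Cl)cc3)n2)cc1`: 76.4%
Compound 3, `Clc1ccc(OCc2ccccc2-c2nc(-c3cccc(Br)c3)cs2)cc1`: 42.9%

All three were tested in a functional assay on the whole organism (strain Wistar albino) for inhibition, with Rattus norvegicus as the target, read by paw edema, at a dose of 10 mg/kg by the oral route; a higher number here means more inhibition at the dose given (going by the name of the read-out), a lower number less inhibition. Compound 1 stands level with compound 2, and these two together give the highest numbers of the three: no change at the digits printed from compound 1 to compound 2 (within the scatter). Compound 3 lies far lower, a number 33.5 percentage points lower from compound 1 to compound 3 (beyond the scatter), and the same gap appears as a number 33.5 percentage points lower from compound 2 to compound 3 (beyond the scatter). Both large steps arise where 3-bromophenyl replaces another group on an aromatic carbon of the shared core.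

Compound 4, `Cc1ccccc1OCc1ccccc1-c1nc(-c2cc(Cl)sc2S(N)(=O)=O)cs1`, has not yet been measured. It differs from compound 1 in one place: 2-methylphenyl in place of 4-chlorophenyl on an oxygen on a saturated carbon. This spot, the oxygen on a saturated carbon, is untouched in every measured step; the two large drops to compound 3 and the flat step to compound 2 all concern a different position. For the measured compounds named here, no measured step therefore bears directly on the change from compound 1 to compound 4, and nothing in the numbers points to one direction over the other. The expected step is a number 6.4 percentage points lower from compound 1 to compound 4 (within the scatter), within the scatter. Compound 4 is accordingly estimated at 70%, with a range from 50% to 85% kept wide for want of any guiding step.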

Compound 4, a percentage reported as inhibition, in the whole organism at one dose (the size of the read-out at that dose, not a potency): 70.1%
The estimate for compound 4 lay 0.1 percentage points below the measured number; low and high end bracket the measured number.
By their numbers in this assay, from the lowest: compound 3; then compounds 4, 1 and 2 (each within the scatter of the next).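

For the compounds shown here, the first step at the oxygen on a saturated carbon, 2-methylphenyl in place of 4-chlorophenyl, reads in this assay as a number 6.3 percentage points lower from compound 1 to compound 4 (within the scatter). The chlorine of compound 1 is therefore not needed at this position to keep the reduction in paw swelling, at least when 2-methylphenyl takes the place of 4-chlorophenyl, and the aromatic ring on this oxygen accepts this one change without a step beyond the scatter. No evidence is at hand to say why the number holds up under this change.

This single step changes both the kind of group on the ring and its place there, so the compounds shown cannot separate the two; 2-chlorophenyl and 4-methylphenyl would pull them apart. They also leave open whether this position needs an aromatic ring of carbon only, or whether the number would hold with a group of another kind on the oxygen, such as a chain ending in an amine or a phenyl ring bearing a carboxylic acid.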